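This account rests on a few compounds, and the source may have more. Where it says the series, first, only, none or still open, it means among the compounds named here.

Among the compounds with values here, compound 2 `O=COC1(C(=O)Nc2ccc([N+](=O)[O-])cc2)CCCCC1` gives 46.3 nM in an ADME assay on WI-38 cells (Homo sapiens) for inhibition, read by MTT assay, with a stated time of 72 h (a higher number here means a weaker inhibitor, a lower number a stronger inhibitor), and stands as the higher of the two numbers so far, a difference within the scatter. Within the data shown here, compound 1 `Cc1ccc(C(=O)OC2(C(=O)Nc3ccc([N+](=O)[O-])cc3)CCCCC2)cc1` gives 32 nM in this assay, and the step of a 1.4-fold higher number from compound 1 to compound 2 (0.16 log units; within the scatter) is the only measured step that bears here. Compound 3 `CCC(=O)OC1(C(=O)Nc2ccc([N+](=O)[O-])cc2)CCCCC1` differs from compound 2 by ethyl in place of hydrogen on a carbonyl carbon, a change at the same carbonyl carbon as the measured step. Since that step, exchanging 4-methylphenyl for hydrogen, stayed within the scatter, the expected step of a 1.2-fold lower number from compound 2 to compound 3 (0.06 log units; within the scatter) is none beyond the scatter. Compound 3 is therefore estimated at 40 nM, with a range of 20 nM to 80 nM.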

Compound 3, half-maximal inhibitory concentration: 44.6 nM
For compound 3 the middle estimate is 1.1-fold (0.05 log units) below the measured one; low and high end bracket the measured number.
By their numbers in this assay, from the lowest: compounds 1, 3 and 2 (each within the scatter of the next).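

In this assay, ethyl in place of hydrogen on the carbonyl carbon gives a 1.0-fold lower number from compound 2 to compound 3 (0.02 log units; within the scatter) and ethyl in place of 4-methylphenyl gives a 1.4-fold higher number from compound 1 to compound 3 (0.14 log units; within the scatter) at the same place. Hydrogen, ethyl and 4-methylphenyl on this carbonyl carbon therefore all lie within the scatter of one another, so a small open chain now reads the same here as the other two groups. Nothing available explains this flat result. Still open, on these data alone, is whether an amine, a carboxylic acid or a longer chain on this carbonyl carbon would stay within the same range.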